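This account rests on a few compounds, and the source may have more. Where it says the series, first, only, none or still open, it means among the compounds named here.

Measured compounds and values:

compound 1 `CC(C)(C)C(=O)N1CCC(NCCSC(c2ccc(F)cc2)c2ccc(F)cc2)CC1` gives 352 nM in an assay on membranes from striatum (strain Sprague-Dawley) for displacement of a labelled ligand from sodium-dependent dopamine transporter (Rattus norvegicus), read by scintillation counting, with a stated time of 120 min; a lower number here means a stronger inhibitor, a higher number a weaker inhibitor; compound 2 `CC(C)(C)CN1CCC(NCCSC(c2ccc(F)cc2)c2ccc(F)cc2)CC1` gives 279 nM; compound 3 `CC(C)(C)C(=O)N1CCC(NCC[S+]([O-])C(c2ccc(F)cc2)c2ccc(F)cc2)CC1` gives 10200 nM.

Compound 1 and compound 2 share a core and differ in one place: neopentyl in place of (tert-butyl)carbonyl on an amine nitrogen in a ring. The step that goes with this change is a 1.3-fold lower number from compound 1 to compound 2 (0.10 log units; within the scatter), so the two values show no difference that can be read as a change. Compound 3 carries a different core; the difference between the core of compound 3 and the core of compound 1 is not broken down here. Compound 3 stands furthest from the others in this assay, beyond the scatter from both compound 1 and compound 2.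

Compound 4 `CC(C)(C)CN1CCC(NCC[S+]([O-])C(c2ccc(F)cc2)c2ccc(F)cc2)CC1` has not yet been measured. It stands to compound 3 as compound 2 stands to compound 1: neopentyl in place of (tert-butyl)carbonyl on an amine nitrogen in a ring. The place lines match word for word, so this is the same change. Since the earlier step of a 1.3-fold lower number from compound 1 to compound 2 (0.10 log units; within the scatter) stayed within the scatter, the step from compound 3 to compound 4 is expected to be small as well, estimated at a 1.3-fold lower number from compound 3 to compound 4 (0.11 log units; within the scatter). Compound 4 is therefore expected to give about 8000 nM in this assay, with a likely range from 3000 nM to 20000 nM.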

Compound 4, inhibition constant: 431 nM
The estimate for compound 4 lay 19-fold (1.27 log units) above the measured number; measured number below the stated range.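

In this assay, neopentyl in place of (tert-butyl)carbonyl on an amine nitrogen in a ring gives a 24-fold lower number from compound 3 to compound 4 (1.37 log units; beyond the scatter). The same change does not carry a single step size from one core to the other: the same change on two cores in this assay, a 1.3-fold lower number (0.10 log units; within the scatter) from compound 1 to compound 2 and a 24-fold lower number (1.37 log units; beyond the scatter) from compound 3 to compound 4, 19-fold (1.27 log units) apart, beyond the scatter of two such steps. In these two pairs, the size of the step therefore depends on the core that carries the change, so a step read on one core is not a safe estimate for the other; the data do not show which feature of the cores sets this difference, and two pairs give no rule for any further core.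

From the compounds shown here alone, it remains open whether the large step on the core of compound 3 is specific to neopentyl and (tert-butyl)carbonyl, or would also appear with an acetyl group or an ethyl chain on the same amine nitrogen. Going by these compounds, it is also open how the same change would behave on a core carrying a sulfone.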